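From 2,6-dimethoxyphenyl to 2,4-dichlorophenyl in the series

The source may hold more compounds than are shown below. What is called first, only, known or untested is meant among the compounds shown, and "the series" means these compounds.

In a functional assay on NCI-H522 cells (Homo sapiens) for inhibition, read by sulforhodamine B assay, with a stated time of 48 h (a lower number here means a stronger inhibitor of growth, a higher number a weaker inhibitor of growth), compound 1 (`O=C(Cc1csc2nc(-c3ccc(Br)cc3)cn12)N/N=C/c1ccccc1`) gives 14100 nM and compound 2 (`O=C(Cc1csc2nc(-c3ccc(Br)cc3)cn12)N/N=C/c1ccccc1O`) gives 5250 nM while compound 3 (`COc1cccc(OC)c1/C=N/NC(=O)Cc1csc2nc(-c3ccc(Br)cc3)cn12`) gives 22900 nM on the same read-out. Compound 3 cannot be separated from compound 1 and stands clearly higher than compound 2. The steps are a 1.6-fold higher number from compound 1 to compound 3 (0.21 log units; within the scatter) and a 4.4-fold higher number from compound 2 to compound 3 (0.64 log units; beyond the scatter) with a 2.7-fold lower number from compound 1 to compound 2 (0.43 log units; beyond the scatter) as the third. Compound 4 (`O=C(Cc1csc2nc(-c3ccc(Br)cc3)cn12)N/N=C/c1ccc(Cl)cc1Cl`) differs from compound 3 as follows: 2,4-dichlorophenyl in place of 2,6-dimethoxyphenyl on a carbon with a double bond to nitrogen on a carbon with a double bond to nitrogen. For the measured compounds named here, no measured step brings in a chlorine-bearing group, so these three steps give only a rough guide to size. The largest is a 4.4-fold higher number from compound 2 to compound 3 (0.64 log units; beyond the scatter) and the expected change is smaller and downward. The expected step is a 2.3-fold lower number from compound 3 to compound 4 (0.36 log units; beyond the scatter) on this estimate. The estimate for compound 4 is 10000 nM with an expected range from 3500 nM to 28000 nM in this assay here.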

Compound 4, concentration for 50% growth inhibition: 25700 nM
Beside the measured number, compound 4's estimate is 2.6-fold (0.41 log units) below it; the measured number falls inside the stated range.
By their numbers in this assay, from the lowest: compound 2; then compounds 1, 3 and 4 (each within the scatter of the next).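

In this assay, 2,4-dichlorophenyl on the carbon with a double bond to nitrogen cannot be separated from 2,6-dimethoxyphenyl (a 1.1-fold higher number from compound 3 to compound 4 (0.05 log units; within the scatter)) or from phenyl (a 1.8-fold higher number from compound 1 to compound 4 (0.26 log units; within the scatter)), so a chlorine-bearing group now sits with these two. The 2-hydroxyphenyl of compound 2 remains apart (a 4.9-fold higher number from compound 2 to compound 4 (0.69 log units; beyond the scatter)), now against three different groups at this position. No measurement available here accounts for this.

The compounds shown leave open whether the lower number of compound 2 belongs to the hydroxy group itself. Going by these compounds, how an amine or a carboxylic acid on this ring would read also stays open.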